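The source may report more compounds than this note shows. Statements on the series, on what has been measured and on what is new or still open speak of the compounds shown alone.

Measured compounds:
compound 1 `CN1CCN(C(=S)SCc2ccc3nc(N)nc(N)c3c2)CC1`: 9200 nM
compound 2 `Nc1nc(N)c2cc(CSC(=S)N3CCN(c4ccccc4Cl)CC3)ccc2n1`: 3610 nM

In a functional assay on A549 cells (Homo sapiens) for antiproliferative activity, read by MTT assay, with a stated time of 72 h (on this read-out lower numbers stand for stronger inhibition and higher numbers for weaker inhibition), compound 1 gives 9200 nM and compound 2 gives 3610 nM. Compound 2 thus holds the lower of the two numbers shown, with compound 1 as its only neighbour: the step of a 2.5-fold lower number from compound 1 to compound 2 (0.41 log units; beyond the scatter) goes with 2-chlorophenyl in place of methyl on an amine nitrogen in a ring.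

Compound 3 `Nc1nc(N)c2cc(CSC(=S)N3CCN(c4ccccc4[N+](=O)[O-])CC3)ccc2n1` has not yet been measured in this assay. It differs from compound 2 in one place: nitro in place of chloro on an aromatic carbon. For the measured compounds named here, no measured step concerns a change of this kind; the one step known, a 2.5-fold lower number from compound 1 to compound 2 (0.41 log units; beyond the scatter), exchanges a whole aryl group for methyl and only shows that an aryl group on that nitrogen sits on the lower side here. For an exchange of one aryl substituent for another there is therefore no guide, and the expected step of a 1.0-fold lower number from compound 2 to compound 3 (0.00 log units; within the scatter) is set within the scatter, in no particular direction. Compound 3 is estimated to give 3600 nM in this assay, with a range from 1500 nM to 9000 nM.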

Compound 3, half-maximal inhibitory concentration: 4360 nM
Compound 3: the middle estimate sits 1.2-fold (0.08 log units) below what was measured, within the range that was stated.
By their numbers in this assay, from the lowest: compounds 2 and 3 (each within the scatter of the next); then compound 1.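

In this assay, putting nitro in place of chloro on this aromatic carbon, ortho to a large group, gives a 1.2-fold higher number from compound 2 to compound 3 (0.08 log units; within the scatter), so this read-out does not separate the two substituents, even though they differ in heavy atoms and hydrogen-bond acceptors. Set beside a 2.5-fold lower number from compound 1 to compound 2 (0.41 log units; beyond the scatter), the new 2.1-fold lower number from compound 1 to compound 3 (0.32 log units; beyond the scatter) shows that the modest move away from the methyl compound, beyond the scatter in both cases, is not confined to the 2-chlorophenyl group and also holds for 2-nitrophenyl. No measurement is available that bears on the reason for this result.

The compounds shown leave open whether a plain phenyl group, with only hydrogen on this carbon, would give a number like those of compound 2 and compound 3, which would decide whether the substituent here contributes anything beyond the aryl group itself. They also leave open whether an amine, a methoxy group or a carboxylic acid on the same carbon would stay as close to compound 2 as nitro does.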